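From 4-fluorophenyl to 4-chlorophenyl: an estimate

This account rests on a few compounds, and the source may have more. Where it says the series, first, only, none or still open, it means among the compounds named here.

All values below come from a functional assay on HepG2 cells (Homo sapiens) for cytotoxicity, read by MTT assay, with a stated time of 48 h (a lower number here means a stronger inhibitor, a higher number a weaker inhibitor), and from no other test.

compound 1 `COc1ccc(-c2nnc(SCCn3c([N+](=O)[O-])cnc3C)o2)cc1` gives 5800 nM
compound 2 `Cc1ncc([N+](=O)[O-])n1CCSc1nnc(-c2ccc([N+](=O)[O-])cc2)o1` gives 4100 nM
compound 3 `Cc1ncc([N+](=O)[O-])n1CCSc1nnc(-c2ccc(F)cc2)o1` gives 600 nM

Compound 3 has the lowest number of the three and is the strongest inhibitor here, since its steps to both others lie beyond the scatter. Compound 4 `Cc1ncc([N+](=O)[O-])n1CCSc1nnc(-c2ccc(Cl)cc2)o1` differs from it in one place, with chloro in place of fluoro on an aromatic carbon, which turns 4-fluorophenyl into 4-chlorophenyl.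

Among the compounds with values here, three measured steps concern that same place. Fluoro in place of methoxy gave a 9.7-fold lower number from compound 1 to compound 3 (0.99 log units; beyond the scatter) and fluoro in place of nitro gave a 6.8-fold lower number from compound 2 to compound 3 (0.83 log units; beyond the scatter) as a second modest step. Nitro in place of methoxy gave a 1.4-fold lower number from compound 1 to compound 2 (0.15 log units; within the scatter) and so does not separate those two groups.

Within the data shown here, no measured compound carries chloro, so these steps guide the estimate only loosely. Among the measured compounds shown here, compound 3 (600 nM) holds the only low number so far, so a higher number is expected for compound 4 in this assay but a smaller step than those two. The expected step is a 2.5-fold higher number from compound 3 to compound 4 (0.40 log units; beyond the scatter) and it remains an estimate. For compound 4 the estimated value is 1500 nM with an expected range from 450 nM to 5000 nM as a rough guide.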

Compound 4, half-maximal inhibitory concentration: 7800 nM
Beside the measured number, compound 4's estimate is 5.2-fold (0.72 log units) below it; the whole stated range lies below it.
By their numbers in this assay, from the lowest: compound 3; then compounds 2, 1 and 4 (each within the scatter of the next).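

In this assay, exchanging fluoro for chloro swaps one heavy atom for one heavy atom, with no change in the counted donors, acceptors or charge, yet it gave a 13-fold higher number from compound 3 to compound 4 (1.11 log units; beyond the scatter), so this position can separate even two halogens. Chloro does not share the low number of fluoro: a 1.9-fold higher number from compound 2 to compound 4 (0.28 log units; within the scatter) and a 1.3-fold higher number from compound 1 to compound 4 (0.13 log units; within the scatter) both lie within the scatter, so chloro, nitro and methoxy cannot be told apart here, while fluoro alone stands out and compound 3 remains the strongest inhibitor of the four. No measurement at hand bears on the reason for this gap between the two halogens.

It remains open whether the low number belongs to fluoro alone, since the compounds shown give no reading for a plain hydrogen, a methyl, a bromo or an amine at this place. Also open, from the compounds shown here alone, is whether chloro in place of fluoro would give a similar step if the chain of the shared core were replaced by a longer chain.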